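The compounds below may be only part of what the source reports. "The series", "measured", "known", "first", "only" and "open" are said of these compounds alone.

In a functional assay on MCF7 cells (Homo sapiens) for antiproliferative activity, read by MTT assay (a higher number here means a weaker inhibitor, a lower number a stronger inhibitor), compound 1 (`COc1ccc(-n2cc(COc3ccc(/C=C/C(=O)c4cc5c(cc4O)OC(C)(C)CC5)cc3)nn2)c([N+](=O)[O-])c1`) gives no single number: it is reported as "not active" (no number reported) and so sits at the inactive end of the scale. In this assay compound 2 (`Cc1c(-n2cc(COc3ccc(/C=C/C(=O)c4ccc5c(c4O)CCC(C)(C)O5)cc3)nn2)cccc1[N+](=O)[O-]`) does give a number, 145000 nM, but it is a high one that marks a weak inhibitor.

Compound 3 (`CCCCCCCCn1cc(COc2ccc(/C=C/C(=O)c3cc4c(cc3O)OC(C)(C)CC4)cc2)nn1`) keeps the core of compound 1 and changes one place. It has octyl in place of 4-methoxy-2-nitrophenyl on an aromatic nitrogen of a five-membered aromatic ring.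

Among the measured compounds shown here, no measured pair shows what this swap does, so what follows is a judgement. Compound 1 offers no number to step from. The expected step in this assay is therefore toward a lower number, a stronger inhibitor, and beyond the usual scatter, though compound 3 could also come back without a number. For the measured compounds named here, the only anchor is compound 2 at 145000 nM, so a modest gain that stays in the weak range seems likely. In this assay the estimate for compound 3 is 50000 nM with an expected range from 12000 nM to 150000 nM around it.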

Compound 3, half-maximal inhibitory concentration: "not active" (no number reported)
Compound 3 has no reported number here; there is nothing to compare the estimate with.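

In this assay, among the compounds shown here, compound 1 and compound 3 are both reported without a number, so no step from 4-methoxy-2-nitrophenyl to octyl can be read. The compounds shown leave open whether any group at this place can give the shared core a measurable potency. Nothing available here explains this result.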